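A few compounds are considered here, and "the series" means these few. Any claim that something is new, unique, unknown or untested is made for them only; others in the source may bear on it.

In an ADME assay, at pH 5 (on this read-out higher numbers stand for a longer-lived compound and lower numbers for a shorter-lived compound), compound 1 `COc1ccnc(C[S+]([O-])c2nc3cc(OC(F)F)ccc3[nH]2)c1C` gives 0.17 h, while compound 2 `COc1cc2[nH]c([S+]([O-])Cc3nccc(OC)c3OC)nc2cc1OC(F)F` gives 2.1 h, the higher of the two numbers and beyond the scatter. Compound 3 `COc1cc2[nH]c([S+]([O-])Cc3nccc(OC)c3C)nc2cc1OC(F)F` differs from compound 2 by methyl in place of methoxy on an aromatic carbon. Within the data shown here, no measured pair isolates this change. However, compound 1 carries the same methyl and gives 0.17 h, so a shorter half-life, beyond the scatter, is expected. The estimated change is an 8.4-fold lower number from compound 2 to compound 3 (0.92 log units; beyond the scatter). For compound 3 the expected half-life in this assay is 0.25 h, with an estimated range of 0.1 h to 0.65 h.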

Compound 3, half-life: 0.2 h
Estimate against measurement, compound 3: 1.3-fold (0.10 log units) above; the measured number falls inside the stated range.
By their numbers in this assay, from the lowest: compounds 1 and 3 (each within the scatter of the next); then compound 2.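

In this assay, methyl in place of methoxy at this position, two atoms from the ring nitrogen, now has a step of its own: an 11-fold lower number from compound 2 to compound 3 (1.02 log units; beyond the scatter), a large change beyond the scatter. Methoxy in place of hydrogen on an aromatic carbon, by contrast, gives a 1.2-fold higher number from compound 1 to compound 3 (0.07 log units; within the scatter), which lies within the scatter. No evidence at hand bears on the cause of either step.

On these data alone, whether an ethyl group or an amine at this position would fall nearer compound 2 or compound 3 stays open. So does whether the methoxy-to-methyl step holds on the core of compound 1.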